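Removing the ethoxycarbonyl group from compound 3

The source may hold more compounds than are shown below. What is called first, only, known or untested is meant among the compounds shown, and "the series" means these compounds.

Measured in an ADME assay on NIH3T3 cells (Mus musculus) for cytotoxicity (on this read-out lower numbers stand for higher toxicity in this test and higher numbers for lower toxicity in this test), all three values being limits of the assay:
- compound 1 `CN(C)CC#Cc1cc2ncnc(Nc3ccc(OCc4cccc(F)c4)c(Cl)c3)c2s1`: > 50 uM
- compound 2 `CC(C)(C)OC(=O)N1CCC[C@H]1C#Cc1cc2ncnc(Nc3ccc(OCc4cccc(F)c4)c(Cl)c3)c2s1`: > 100 uM
- compound 3 `CCOC(=O)CN(C)CC#Cc1cc2c(Nc3ccc(OCc4cccc(F)c4)c(Cl)c3)ncnc2s1`: > 50 uM

Compound 3 stands only at a limit, > 50 uM. (the limit of > 50 uM in this assay, at which 2 of the 3 values shown sit).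

Compound 4 `CN(C)CC#Cc1cc2c(Nc3ccc(OCc4cccc(F)c4)c(Cl)c3)ncnc2s1` carries hydrogen in place of ethoxycarbonyl on a saturated chain carbon bound to an amine nitrogen. The resulting (dimethylamino)methyl also stands in compound 1, which gives the limit > 50 uM. Among the compounds with values here, the only measured step, a step that the two limits leave unreadable from compound 1 to compound 2, has no readable size. The expected change is a number no higher from compound 3 to compound 4 (the limit leaves the size open), and no shift beyond the usual scatter is expected in either direction in this assay. For compound 4 the estimate is 50 uM, with an expected range of 20 uM to 100 uM.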

Compound 4, half-maximal toxic concentration: 41 uM
Compound 4: the middle estimate sits 1.2-fold (0.09 log units) above what was measured; the range from low to high includes it.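

In this assay, within the data shown here, compound 4 gives 41 uM, the first value in this set that is a number and not a limit. Hydrogen in place of ethoxycarbonyl on this saturated chain carbon gives an at least 1.2-fold lower number from compound 3 to compound 4 (0.08 log units; that floor lies within the scatter). That shows no change beyond the scatter at this position, yet the true size stays open, because the value of compound 3 is only a limit: the limit of > 50 uM in this assay, at which 2 of the 4 values shown sit.

The step between compound 1 and compound 2 cannot be read either. As far as these compounds go, how a carboxylic acid or a longer chain at this place would read in this assay remains open.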